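A Methoxy Added to the Benzylsulfanyl Arm

A few compounds are considered here, and "the series" means these few. Any claim that something is new, unique, unknown or untested is made for them only; others in the source may bear on it.

Of the compounds shown here, three have been measured in a functional assay on PC-3 cells (Homo sapiens) for cytotoxicity, read by MTT assay; a higher number here means a weaker inhibitor, a lower number a stronger inhibitor. Compound 1 `COc1ccc2cc([C@H](C)c3nnc(SCc4ccccc4)n3-c3ccc(Cl)cc3)ccc2c1` gives 14200 nM, the lowest of the three numbers. Compound 3 `COc1ccc2cc([C@H](C)c3nnc(SCc4c(Cl)cccc4Cl)n3-c3cccc(Cl)c3)ccc2c1` gives 165000 nM, and compound 2 `COc1ccc(CSc2nnc([C@@H](C)c3ccc4cc(OC)ccc4c3)n2-c2ccc(F)cc2)cc1` gives 400000 nM. Both gaps to compound 1 lie beyond the scatter. Compound 4 `COc1cccc(CSc2nnc([C@@H](C)c3ccc4cc(OC)ccc4c3)n2-c2ccc(Cl)cc2)c1` has not yet been measured. It differs from compound 1 in one place: methoxy in place of hydrogen on an aromatic carbon. Among the measured compounds shown here, no step between measured compounds isolates this change. Compound 2 and compound 3, which carry substituents on the benzyl group alongside other changes, give higher numbers than compound 1, so a step toward a higher number in this assay seems more likely than one toward a lower, though it may stay within the scatter. Compound 4 is expected to give 35000 nM, with a range from 10000 nM to 150000 nM. This implies an expected step of a 2.5-fold higher number from compound 1 to compound 4 (0.39 log units; beyond the scatter).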

Compound 4, half-maximal inhibitory concentration: 138000 nM
Estimate against measurement, compound 4: 3.9-fold (0.60 log units) below; the range from low to high includes it.
By their numbers in this assay, from the lowest: compound 1; then compounds 4 and 3 (each within the scatter of the next); then compound 2.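

Replacing hydrogen with methoxy, which turns benzylsulfanyl into (3-methoxybenzyl)sulfanyl, gives in this assay a 9.7-fold higher number from compound 1 to compound 4 (0.99 log units; beyond the scatter) as a single change. This is the first step that isolates a substitution on the benzyl group, so the position is shown to respond to this change alone, without the other differences carried by compound 2 and compound 3. Nothing measured here bears on why the step has this size. On these data alone, whether a hydroxyl or an amine at the same place would give a similar number remains open.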